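This account rests on a few compounds, and the source may have more. Where it says the series, first, only, none or still open, it means among the compounds named here.

Measured so far:

Compound 1, `CN(C)CCCNc1nc(-c2ccc(NC(=O)Nc3ccccc3F)cc2)nc2ccsc12`: 660 nM
Compound 2, `CN(C)CCCNc1nc(-c2ccc(NC(=O)Nc3ccccc3Cl)cc2)nc2ccsc12`: 590 nM
Compound 3, `CCN(CC)CCCNc1nc(-c2ccc(NC(=O)Nc3ccc(F)cc3)cc2)nc2c(Cl)c(Cl)sc12`: 1630 nM

All three were tested in a functional assay on MDA-MB-231 cells (Homo sapiens) for cytotoxicity, read by MTT assay, with a stated time of 72 h; a higher number here means a weaker inhibitor, a lower number a stronger inhibitor. Compound 1 and compound 2 share one core and differ only in one group: chloro in place of fluoro on an aromatic carbon. That exchange made a step of a 1.1-fold lower number from compound 1 to compound 2 (0.05 log units; within the scatter), so the two compounds cannot be told apart by this measurement. Compound 3 carries a different core; the difference between the two cores is not broken down here. In this assay compound 3 gives 1630 nM, the highest of the three numbers.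

Compound 4, `CCN(CC)CCCNc1nc(-c2ccc(NC(=O)Nc3ccc(Cl)cc3)cc2)nc2c(Cl)c(Cl)sc12`, is not yet measured. It is made from compound 3 by chloro in place of fluoro on an aromatic carbon. Among the measured compounds shown here, this is the same kind of change as the one from compound 1 to compound 2, not the same one, since in that pair the group sits ortho to a large group, while here it sits para to a large group. Resting on the step of a 1.1-fold lower number from compound 1 to compound 2 (0.05 log units; within the scatter), compound 4 is expected to stay close to compound 3, with an expected step of a 1.1-fold lower number from compound 3 to compound 4 (0.04 log units; within the scatter). The estimate for compound 4 in this assay is 1500 nM, expected to lie between 700 nM and 3200 nM.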

Compound 4, half-maximal inhibitory concentration: 660 nM
Compound 4: middle estimate off by 2.3-fold (0.36 log units), on the high side; the whole stated range lies above it.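

In this assay, placing chloro where fluoro stood on the 4-fluorophenyl group gave a 2.5-fold lower number from compound 3 to compound 4 (0.39 log units; beyond the scatter), a step that lies beyond the usual scatter, whereas the same kind of exchange on the core of compound 1 gave a 1.1-fold lower number from compound 1 to compound 2 (0.05 log units; within the scatter), which lies within it. Read one at a time, the two steps seem to disagree, but set side by side they cannot be told apart: the same change on two cores in this assay, a 1.1-fold lower number (0.05 log units; within the scatter) from compound 1 to compound 2 and a 2.5-fold lower number (0.39 log units; beyond the scatter) from compound 3 to compound 4, 2.2-fold (0.34 log units) apart, within the scatter of two such steps. Among the compounds shown here, this means the data do not show that the core changes what this exchange does, yet two pairs are too few to show that the exchange carries over unchanged, and in compound 4 the chloro sits para to a large group, a different place from the one it holds in compound 2.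

Still open, going by these compounds, is how the step would read with fluoro and chloro para to a large group on the core of compound 1, which would separate the effect of the core from that of the place. Also open, on these data alone, is how a bromo or a methoxy group would compare at that same place on either core.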